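The source may hold more compounds than are shown below. What is called first, only, known or untested is meant among the compounds shown, and "the series" means these compounds.

Of the compounds shown here, three built on one shared core have been measured in an assay on isolated protein for inhibition of Amine oxidase [flavin-containing] B (Homo sapiens); on this read-out higher numbers stand for weaker inhibition and lower numbers for stronger inhibition. Compound 1 `C#CCNC1CCc2c(SCc3cccc(F)c3)cccc21` gives 1480 nM, compound 2 `C#CCNC1CCc2c(SCc3ccc(Br)cc3)cccc21` gives 1310 nM, and compound 3 `C#CCNC1CCc2c(SCc3ccc(C(F)(F)F)cc3)cccc21` gives 9680 nM, the highest of the three numbers. One measured step, a 1.1-fold lower number from compound 1 to compound 2 (0.05 log units; within the scatter), changed the aryl group without moving the number beyond the scatter; the other, a 7.4-fold higher number from compound 2 to compound 3 (0.87 log units; beyond the scatter), put a trifluoromethyl onto the aromatic carbon and raised the number clearly.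

Compound 4 `C#CCNC1CCc2c(SCc3ccc(C)cc3)cccc21` differs from compound 3 by methyl in place of trifluoromethyl on an aromatic carbon, on an aromatic carbon para to a large group. The step of a 7.4-fold higher number from compound 2 to compound 3 (0.87 log units; beyond the scatter) bears most directly on this change, as it records what the arrival of trifluoromethyl did at that position. Swapping it for methyl is therefore expected to lower the number in this assay, roughly undoing the earlier rise and bringing compound 4 back toward the level of compound 1 and compound 2. For compound 4 the expected step is a 4.8-fold lower number from compound 3 to compound 4 (0.68 log units; beyond the scatter). Compound 4 is accordingly estimated at 2000 nM, most likely between 800 nM and 5000 nM.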

Compound 4, half-maximal inhibitory concentration: 1560 nM
The estimate for compound 4 lay 1.3-fold (0.11 log units) above the measured number; the range from low to high includes it.
By their numbers in this assay, from the lowest: compounds 2, 1 and 4 (each within the scatter of the next); then compound 3.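

In this assay, methyl in place of trifluoromethyl on an aromatic carbon para to a large group gives a 6.2-fold lower number from compound 3 to compound 4 (0.79 log units; beyond the scatter), so the rise seen with trifluoromethyl at this place does not appear with methyl. Compound 4 cannot be told apart from its neighbours, with a 1.2-fold higher number from compound 2 to compound 4 (0.08 log units; within the scatter) and a 1.1-fold higher number from compound 1 to compound 4 (0.02 log units; within the scatter), both within the scatter, and among these four compounds only compound 3 stands apart. Nothing available here explains why trifluoromethyl behaves differently from methyl and bromo.

Still open, as far as these compounds go, is whether the higher number belongs to trifluoromethyl alone or would return with other groups at this place, such as a methoxy group, an amine or a carboxylic acid. It is also unknown whether a longer chain in place of methyl would leave the number where compound 4 has it.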